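The source may report more compounds than this note shows. Statements on the series, on what has been measured and on what is new or still open speak of the compounds shown alone.

Values in a physicochemical assay for solubility (a higher number here means a more soluble compound, a lower number a less soluble compound), for the compounds measured so far
Compound 1 `CC(=O)N1CCC[C@H]1C(=O)N1CCC(NS(=O)(=O)c2cc(S(=O)(=O)c3ccccc3)ccc2C(F)(F)F)CC1` gives 12500 nM
Compound 2 `O=C([C@@H]1CCCN1C(=O)c1ccncc1)N1CCC(NS(=O)(=O)c2cc(S(=O)(=O)c3ccccc3)ccc2C(F)(F)F)CC1` gives 100000 nM
Compound 3 `CCNC(=O)N1CCC[C@H]1C(=O)N1CCC(NS(=O)(=O)c2cc(S(=O)(=O)c3ccccc3)ccc2C(F)(F)F)CC1` gives 100000 nM

Compound 3 shares the highest of these three numbers with compound 2 (the step is no change at the digits printed from compound 2 to compound 3 (within the scatter)) and stands well clear of compound 1 (an 8.0-fold higher number from compound 1 to compound 3 (0.90 log units; beyond the scatter)). The next compound, compound 4 `CC(C)(C)NC(=O)N1CCC[C@H]1C(=O)N1CCC(NS(=O)(=O)c2cc(S(=O)(=O)c3ccccc3)ccc2C(F)(F)F)CC1`, keeps all of compound 3 except for one group, with tert-butyl in place of ethyl on an amide-type nitrogen.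

Among the compounds with values here, no measured step swaps ethyl for another chain at this spot, so the evidence is indirect. The closest guides are changes on the neighbouring carbonyl carbon. These are an 8.0-fold higher number from compound 1 to compound 3 (0.90 log units; beyond the scatter) for ethylamino in place of methyl and an 8.0-fold higher number from compound 1 to compound 2 (0.90 log units; beyond the scatter) for pyridin-4-yl in place of methyl. Two quite different groups thus gave the same number, while only the methyl of compound 1 gave a lower one. A rise in this assay looks unlikely because compound 3 already gives 100000 nM at the top of the values seen so far. A small fall is the more likely outcome, no larger than those measured steps and possibly within the scatter. Within the data shown here, the estimated step is a 1.7-fold lower number from compound 3 to compound 4 (0.22 log units; within the scatter) (an expectation with no direct precedent). The estimated value for compound 4 is 60000 nM (expected range 15000 nM to 120000 nM).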

Compound 4, solubility: 50000 nM
Estimate against measurement, compound 4: 1.2-fold (0.08 log units) above; the measured number falls inside the stated range.
By their numbers in this assay, from the lowest: compound 1; then compounds 4, 2 and 3 (each within the scatter of the next).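

In this assay, within the data shown here, the swap on the amide-type nitrogen itself, from ethyl with 2 heavy atoms to tert-butyl with 4, gives a 2.0-fold lower number from compound 3 to compound 4 (0.30 log units; within the scatter), the first direct reading at this spot. Set against the pyridin-4-yl group on the carbonyl carbon, (tert-butyl)amino gives a 2.0-fold lower number from compound 2 to compound 4 (0.30 log units; within the scatter), so ethylamino, (tert-butyl)amino and pyridin-4-yl cannot be told apart in this assay, despite their different shapes and sizes. Methyl on the carbonyl carbon remains the one group that stands apart, with a 4.0-fold higher number from compound 1 to compound 4 (0.60 log units; beyond the scatter), which makes compound 1 the lowest of the four and places all three replacements clearly above it.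

Nothing shown here explains why methyl differs from the other three groups. From the compounds shown here alone, it also remains open whether a cyclohexyl ring, a longer chain such as n-octyl, or a carboxylic acid on the amide-type nitrogen would stay level with ethyl and tert-butyl, or would instead bring the number down towards that of compound 1.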